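Allyloxycarbonyl to acetyl: what to expect for compound 4

A few compounds are considered here, and "the series" means these few. Any claim that something is new, unique, unknown or untested is made for them only; others in the source may bear on it.

Measured in a functional assay on HEK293 cells for antagonist activity at Voltage-dependent L-type calcium channel subunit alpha-1D (Rattus norvegicus), read by FLIPR; on this read-out lower numbers stand for stronger inhibition and higher numbers for weaker inhibition:
- compound 1 `CCCC1=C(C(=O)OCC)C(c2cccc([N+](=O)[O-])c2)C(C(=O)OCC)=C(C)N1` gives 105 nM
- compound 2 `COC(=O)C1=C(C)NC(C)=C(C(=O)OCCCCc2ccc(OC)cc2)C1c1cccc([N+](=O)[O-])c1` gives 38 nM
- compound 3 `C=CCOC(=O)C1=C(C)NC(C)=C(C(=O)OCC)C1c1ccc2ccccc2c1` gives 2160 nM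

Compound 3 stands at the highest number of the three, well beyond the scatter from compound 1 and further still from compound 2. Compound 4 `CCOC(=O)C1=C(C)NC(C)=C(C(C)=O)C1c1ccc2ccccc2c1` differs from compound 3 in one place: methyl in place of allyloxy on a carbonyl carbon, that is, allyloxycarbonyl to acetyl. Going by the values given here, no measured pair shows this kind of change, so no step can be quoted for it; the three measured compounds differ from one another in several places at once. Compound 4 is therefore expected to stay close to compound 3, with a step of a 1.4-fold higher number from compound 3 to compound 4 (0.14 log units; within the scatter) that is estimated to be small and, if anything, toward a higher number. Compound 4 is estimated at 3000 nM, within the range 700 nM to 13000 nM.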

Compound 4, half-maximal inhibitory concentration: 2320 nM
Compound 4: middle estimate off by 1.3-fold (0.11 log units), on the high side; measured number inside the range.
By their numbers in this assay, from the lowest: compound 2; then compound 1; then compounds 3 and 4 (each within the scatter of the next).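

In this assay, going by these compounds alone, the swap of allyloxy for methyl on a carbonyl carbon gives a 1.1-fold higher number from compound 3 to compound 4 (0.03 log units; within the scatter) and thus isolates this position for the first time. With the rest of compound 3 held constant, removing the allyloxy oxygen and double bond leaves the number within the scatter. Nothing available explains this result.

The compounds shown leave open whether this holds for other groups on this carbonyl carbon, such as an amine or a longer chain ending in a carboxylic acid. They also leave open whether the same swap reads alike on the core of compound 2.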